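A few compounds are considered here, and "the series" means these few. Any claim that something is new, unique, unknown or untested is made for them only; others in the source may bear on it.

Working notes on the series, read in a functional assay on HepG2 cells (Homo sapiens) for antiproliferative activity, read by MTT assay, with a stated time of 72 h; on this read-out higher numbers stand for weaker inhibition and lower numbers for stronger inhibition. Compound 1 (`CCOC(=O)c1csc2nc(CN3CCN(C)CC3)c(-c3ccc(C)cc3)n12`) gives 53600 nM. Compound 2 (`CCOC(=O)c1csc2nc(CN3CCN(C)CC3)c(-c3ccc(OC)cc3)n12`) gives 68400 nM. With only these two numbers available, compound 2 stands within the scatter of compound 1, so no order can be read between them.

The next step leads to compound 3 (`CCOC(=O)c1csc2nc(CN3CCN(C)CC3)c(-c3ccc(Br)cc3)n12`), which is still unmeasured. The change is bromo in place of methoxy on an aromatic carbon, para to a large group, or 4-methoxyphenyl to 4-bromophenyl.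

Within the data shown here, one measured step bears on it, the swap of methyl for methoxy at that same place: a 1.3-fold higher number from compound 1 to compound 2 (0.11 log units; within the scatter). That step stays within the scatter. Among the measured compounds shown here, no bromo compound has been measured, so the evidence for this exact change is indirect. On the strength of that single small step, no shift beyond the scatter is expected in this assay, and no direction is favoured.

The estimated step is a 1.2-fold lower number from compound 2 to compound 3 (0.07 log units; within the scatter). For compound 3 the estimate is 58000 nM, with an expected range of 28000 nM to 110000 nM.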

Compound 3, half-maximal inhibitory concentration: 82700 nM
Compound 3: middle estimate off by 1.4-fold (0.15 log units), on the low side; low and high end bracket the measured number.
By their numbers in this assay, from the lowest: compounds 1, 2 and 3 (each within the scatter of the next).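

In this assay, bromo joins methyl and methoxy at this place, on an aromatic carbon of a six-membered aromatic ring of carbon only, para to a large group, and both new steps stay within the scatter (a 1.2-fold higher number from compound 2 to compound 3 (0.08 log units; within the scatter); a 1.5-fold higher number from compound 1 to compound 3 (0.19 log units; within the scatter)). The three compounds therefore cannot be put in any order, and the position shows no measurable preference among these three groups in this read-out. The change from 4-methoxyphenyl to 4-bromophenyl replaces 2 heavy atoms and 1 hydrogen-bond acceptor with 1 heavy atom and no acceptor without a shift beyond the scatter, and no accompanying measurement speaks to the reason for this.

As far as these compounds go, it remains open whether any group at this place can move the number beyond the scatter, for example an amine, a carboxylic acid or a longer alkoxy chain such as butoxy. The compounds shown also say nothing about changes elsewhere on the shared core, such as replacing the ethyl ester with an amide or the methylpiperazine with morpholine.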